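Swapping a Hydroxyphenyl for a Methoxyphenyl: An Untested Direction

The compounds below may be only part of what the source reports. "The series", "measured", "known", "first", "only" and "open" are said of these compounds alone.

Measured so far in a functional assay on cells (Leukemia cell, Homo sapiens) for cytotoxicity, read by sulforhodamine B assay, with a stated time of 48 h; a lower number here means a stronger inhibitor of growth, a higher number a weaker inhibitor of growth:
compound 1, `O=C1N=C(N2N=C(c3ccccc3)CC2c2ccccc2O)S/C1=C1/C(=O)Nc2ccccc21`, gives 3190 nM
compound 2, `O=C1N=C(N2N=C(c3ccccc3)CC2c2ccccc2O)S/C1=C1/C(=O)Nc2ccc(Br)cc21`, gives 270 nM

Compound 1 has the highest of the two numbers in this assay. Among the measured compounds shown here, its only neighbour is compound 2, and the step of a 12-fold lower number from compound 1 to compound 2 (1.07 log units; beyond the scatter) comes from a single change, bromo in place of hydrogen on an aromatic carbon of the shared core.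

Compound 3, `COc1ccc(C2CC(c3ccccc3)=NN2C2=NC(=O)/C(=C3\C(=O)Nc4ccccc43)S2)cc1`, has not yet been measured. It differs from compound 1 in one place: 4-methoxyphenyl in place of 2-hydroxyphenyl on a saturated ring carbon. This change sits on a saturated ring carbon of the five-membered ring with two nitrogens, a different part of the molecule from where the bromo step was made. For the measured compounds named here, no measured step bears on an exchange at this position, so nothing here shows whether it raises or lowers the number. Going by the values given here, the one known step is large, but it concerns another ring and gives no guidance for this one.

With no relevant comparison, compound 3 is expected to land near compound 1, at an estimated 3190 nM with a range of 1000 nM to 10000 nM. The expected step is no change at the digits printed from compound 1 to compound 3 (within the scatter), that is, none beyond the scatter.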

Compound 3, concentration for 50% growth inhibition: 1640 nM
Estimate against measurement, compound 3: 1.9-fold (0.29 log units) above; the measured number falls inside the stated range.
By their numbers in this assay, from the lowest: compound 2; then compounds 3 and 1 (each within the scatter of the next).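

In this assay, among the compounds shown here, exchanging 2-hydroxyphenyl for 4-methoxyphenyl on the saturated ring carbon leaves the number within the scatter (a 1.9-fold lower number from compound 1 to compound 3 (0.29 log units; within the scatter)), which is the first reading at this position. So this one exchange, unlike the bromo step on the other part of the molecule, produces no change that can be told apart from repeat-to-repeat variation, even though the hydrogen-bond donor of the 2-hydroxyphenyl is absent from the 4-methoxyphenyl. No measurement offers an explanation for this result.

This single pair changes the oxygen-bearing group and its place on the aromatic ring together, so the compounds shown do not separate those two changes, and one exchange cannot say how tolerant the position is in general. Also open, as far as these compounds go, are how an amine or a carboxylic acid on this aromatic ring would read, and whether the bromo step would hold with 4-methoxyphenyl in place.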